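Removing the Acetyl from Compound 1

A few compounds are considered here, and "the series" means these few. Any claim that something is new, unique, unknown or untested is made for them only; others in the source may bear on it.

In a functional assay on HCT-15 cells (Homo sapiens) for cytotoxicity, read by sulforhodamine B assay (on this read-out higher numbers stand for an effect only at larger amounts of compound and lower numbers for an effect already at smaller amounts), compound 1 `C=C[C@@](C)(CC[C@H]1C(C)=CC[C@H]2C(C)(C)CCC[C@]12C)O[C@@H]1O[C@@H](C)[C@@H](OC(C)=O)[C@H](O)[C@H]1O` gives 3.1 ug/mL, the lowest of the two numbers shown. Compound 3 `C=C[C@@](C)(CC[C@H]1C(C)=CC[C@H]2C(C)(C)CCC[C@]12C)O[C@@H]1O[C@H](C)[C@H](OC(C)=O)[C@H](O)[C@H]1O` has the same atoms and bonds and gives 4.1 ug/mL in this assay; the step of a 1.3-fold higher number from compound 1 to compound 3 (0.12 log units; within the scatter) sits within the scatter, and the fact that compounds 1 and 3 differ only in the configuration as drawn is all that separates the two. Compound 2 `C=C[C@](C)(O)CC[C@H]1C(=C)[C@H](O)C[C@H]2C(C)(C)CCC[C@]12C` reaches only a limit in this assay, > 5 ug/mL. Compound 4 `C=C[C@@](C)(CC[C@H]1C(C)=CC[C@H]2C(C)(C)CCC[C@]12C)O[C@@H]1O[C@@H](C)[C@@H](O)[C@H](O)[C@H]1O` differs from compound 1 by hydrogen in place of acetyl on an oxygen on a saturated carbon. No measured step removes an acetyl, so nothing shown speaks directly to this change; the one single-place step in this assay was within the scatter. Compound 4 is therefore expected to give about 4 ug/mL, between 1.5 ug/mL and 10 ug/mL. This expected change corresponds to a 1.3-fold higher number from compound 1 to compound 4 (0.11 log units; within the scatter).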

Compound 4, concentration for half-maximal effect: 3.2 ug/mL
Compound 4: the middle estimate sits 1.3-fold (0.10 log units) above what was measured, and the stated range covers the measured number.
By their numbers in this assay, from the lowest: compounds 1, 4 and 3 (each within the scatter of the next). At a limit, above all of these: compound 2.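

In this assay, among these compounds, the step of a 1.0-fold higher number from compound 1 to compound 4 (0.01 log units; within the scatter) is the first measured change at this position, on an oxygen on a saturated carbon. It shows that going from acetoxy to hydroxy leaves the number within the scatter, so the acetyl is not needed for this level of cytotoxicity. Nothing shown gives a reason for this result. As far as these compounds go, whether a benzoyl or a longer acyl chain in place of the acetyl would also leave the number within the scatter stays open.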